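Swapping one aromatic end group on compound 2

The compounds below may be only part of what the source reports. "The series", "measured", "known", "first", "only" and "open" are said of these compounds alone.

Results so far in a functional assay on NCI-H1299 cells (Homo sapiens) for inhibition, read by CCK-8 assay, with a stated time of 72 h, tested at 1 uM; on this read-out lower numbers stand for less inhibition of growth and higher numbers for more inhibition of growth at the one concentration tested
Compound 1 `CN(C)C(=O)c1cc2cnc(Nc3ccc(N)cn3)nc2n1C1CCCC1` gives 60.1%
Compound 2 `CN(C)C(=O)c1cc2cnc(Nc3ccc(NC(=O)C4(C(=O)Nc5cccc(O)c5)CC4)cc3)nc2n1C1CCCC1` gives 77.5%
Compound 3 `Nc1ccc(NC(=O)C2(C(=O)Nc3ccc(F)cc3)CC2)cc1F` gives 46.2%

Of these three, compound 2 at 77.5% stands highest, and compound 1 and compound 3 both lie lower by more than the usual scatter of such measurements.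

The next molecule, compound 4 `CN(C)C(=O)c1cc2cnc(Nc3ccc(NC(=O)C4(C(=O)Nc5ccc(Cl)c(C(F)(F)F)c5)CC4)cc3)nc2n1C1CCCC1`, keeps the core of compound 2 and changes one end: 4-chloro-3-(trifluoromethyl)phenyl in place of 3-hydroxyphenyl on an amide-type nitrogen. Both groups are one six-membered aromatic ring of carbon only, so the ring type stays while the groups on it differ.

Among the measured compounds shown here, no two measured compounds differ in only one place, so nothing measured yet shows directly what such a swap does. The expectation therefore rests on the retained core, which compound 1 also carries, and compound 1 gives 60.1% without this amide end. That suggests the core carries much of the effect, though three compounds are thin evidence. A small fall, within the usual scatter, is expected, and the estimated change is a number 5.5 percentage points lower from compound 2 to compound 4 (within the scatter) in this assay on this swap. Compound 4 is estimated at 72%, with an expected range of 52% to 90%.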

Compound 4, percent growth inhibition at one concentration: 39.5%
Estimate against measurement, compound 4: 32.5 percentage points above; the measured number lies below the stated range.
By their numbers in this assay, from the lowest: compounds 4 and 3 (each within the scatter of the next); then compound 1; then compound 2.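

In this assay, among the compounds shown here, placing 4-chloro-3-(trifluoromethyl)phenyl where 3-hydroxyphenyl stood on the amide-type nitrogen gives a number 38 percentage points lower from compound 2 to compound 4 (beyond the scatter), the first direct comparison in this set of compounds that differ in only one place. It shows that this end of the molecule has a large influence on the read-out: with the shared core unchanged and the carbon-only aromatic ring retained, the groups on that ring are enough to shift the number well beyond the scatter, so the core alone does not fix the result. The swap changes several things at once, from 7 to 11 heavy atoms and from 1 hydrogen-bond donor to 0, and no data shown explain why growth inhibition falls.

This single step cannot separate the loss of the hydroxyl group from the arrival of the chlorine and trifluoromethyl groups. Plain phenyl would help to divide these contributions, as would a ring carrying only a chlorine, only a trifluoromethyl group, a methoxy group or an amine, and whether any of these would keep growth inhibition near the level of compound 2 remains open.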